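Hydroxy to Acetyl at the End of the Side Chain

The source may report more compounds than this note shows. Statements on the series, on what has been measured and on what is new or still open speak of the compounds shown alone.

compound 1, `CCCn1c(=O)n(C)c(=O)c2c1ncn2CCC(=O)O`: > 200000 nM
compound 2, `CCCn1c(=O)n(C)c(=O)c2c1ncn2CCO`: 41400 nM

Both compounds were tested in an assay on Cerebral cortex for binding affinity to adenosine receptor A1 (Cavia porcellus), read by radioligand binding; a higher number here means a weaker inhibitor, a lower number a stronger inhibitor. Compound 1 gives no number there, only a limit, > 200000 nM. Compound 2 gives 41400 nM. The step between them, an at least 4.8-fold lower number from compound 1 to compound 2 (0.68 log units; beyond the scatter), can be stated only as a bound because of the limit of > 200000 nM in this assay, at which 1 of the 2 values shown sits. Going by the values given here, compound 2 therefore stands as the single compound with a real number in this assay; the other result is a limit.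

Compound 3 `CCCn1c(=O)n(C)c(=O)c2c1ncn2CCC(C)=O` is not yet measured. It differs from compound 2 by acetyl in place of hydroxy on a saturated chain carbon, two bonds along the chain from an aromatic nitrogen. Among the compounds with values here, the only measured step, from carboxy to hydroxy, removed the charged group and gave an at least modest improvement; it bears on the new change only loosely, since here a hydroxy gives way to acetyl, which keeps an acceptor but loses the donor. Within the data shown here, no measured step shows what that does, so no movement beyond the scatter is expected in this assay; the estimated step is a 1.4-fold lower number from compound 2 to compound 3 (0.14 log units; within the scatter). Compound 3 is expected at about 30000 nM, within 8000 nM to 120000 nM.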

Compound 3, inhibition constant: 30000 nM
Compound 3: middle estimate and measured number agree at the digits printed; the range from low to high includes it.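

With hydroxy replaced by acetyl on the saturated chain carbon, this assay shows a 1.4-fold lower number from compound 2 to compound 3 (0.14 log units; within the scatter), so at this position the result does not separate a group with a hydrogen-bond donor from acetyl, which has none. Going by these compounds alone, compound 3 also gives the first comparison that keeps the carbonyl of compound 1 and changes only what sits on it: methyl in place of hydroxy on the carbonyl carbon gives an at least 6.6-fold lower number from compound 1 to compound 3 (0.82 log units; beyond the scatter), so a carbonyl at this place in the chain does not by itself go with the weak result of compound 1. That step is a lower bound and its true size cannot be read, because compound 1 has only a limit: the limit of > 200000 nM in this assay, at which 1 of the 3 values shown sits.

The compounds shown leave open whether an amine or a methyl ether at the end of the side chain would move the number beyond the scatter from where compound 2 and compound 3 stand. They also leave open whether a longer chain carrying the same acetyl would do so, and how any of these changes would read at other adenosine receptors.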